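Cytotoxicity of an Aryl Urea Series, Before the Next Result

The source may report more compounds than this note shows. Statements on the series, on what has been measured and on what is new or still open speak of the compounds shown alone.

The series is built on one shared core, carried into a set of ureas that differ only in the aryl group on the urea nitrogen. Compound 1 `Cc1cc(NC(=O)Nc2cc(F)ccc2F)c2ccccc2n1` sits at the limit in an ADME assay on HepG2 cells (Homo sapiens) for cytotoxicity, with a stated time of 72 h (a lower number here means that less compound is needed, a higher number that more compound is needed for the effect), giving > 25000 nM. Compound 2 `Cc1cc(NC(=O)Nc2ccccc2F)c2ccccc2n1` likewise reaches only the limit of this assay, at > 25000 nM. Compound 3 `CSc1ccccc1NC(=O)Nc1cc(C)nc2ccccc12` again stops at the limit, with > 25000 nM. Compound 2 therefore stands where every measured member stands: at the limit of > 25000 nM in this assay, at which 3 of the 3 values shown sit, with no number to place it above or below its neighbours. The two measured steps, a step that the two limits leave unreadable from compound 1 to compound 2 and a step that the two limits leave unreadable from compound 2 to compound 3, are both unreadable for the same reason, since each joins two limits.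

Compound 4 `Cc1cc(NC(=O)Nc2ccc(Cl)cc2)c2ccccc2n1` is the next member. It differs from compound 2 as follows: 4-chlorophenyl in place of 2-fluorophenyl on an amide-type nitrogen. Neither measured step offers a readable size to transfer, so no direction can be drawn from them; what they do show is that three different aryl groups on this nitrogen all left the cells unaffected up to the limit. On that basis compound 4 is expected to behave the same way in this assay, with the step that the limit leaves unreadable from compound 2 to compound 4 estimated to be none beyond the scatter. The estimate for compound 4 is 30000 nM, within a range from 10000 nM to 100000 nM.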

Compound 4, half-maximal effective concentration: > 25000 nM
Compound 4 was reported as a limit; the forecaster's own chance of this, stated with the estimate: 80%; the middle value is on the limit's open side.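

In this assay compound 4 gives > 25000 nM, which is a limit of the assay. No new step can be read between compound 2 and compound 4, because both stand at the same limit: the limit of > 25000 nM in this assay, at which 4 of the 4 values shown sit. The compounds shown leave open whether any aryl group on this urea nitrogen would give a measurable effect in this assay.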